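The source may hold more compounds than are shown below. What is called first, only, known or untested is meant among the compounds shown, and "the series" means these compounds.

Three compounds that share one core have been examined in an ADME assay on Huh-7 cells (Homo sapiens) for cytotoxicity; on this read-out lower numbers stand for stronger inhibition and higher numbers for weaker inhibition. Compound 1 `CN(c1cc2ncc(=O)[nH]c2cc1NC(=O)Nc1ccccc1)C1CCCCC1` gives 5520 nM in this assay. Compound 2 `CN(c1cc2ncc(=O)[nH]c2cc1NC(=O)Nc1cccc2ccccc12)C1CCCCC1` carries a naphthalen-1-yl in place of phenyl on an amide-type nitrogen and gives 5330 nM; the step of a 1.0-fold lower number from compound 1 to compound 2 (0.02 log units; within the scatter) is within the scatter. Compound 3 `CN(c1cc2ncc(=O)[nH]c2cc1N1C(=O)CN(c2cccc3ccccc23)C1=S)C1CCCCC1` gives 11200 nM, so compound 1 sits with a lower number than compound 3 and within the scatter of compound 2.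

Compound 4 `CN(c1cc2ncc(=O)[nH]c2cc1Nc1nc(-c2cccs2)cs1)C1CCCCC1` has not yet been measured in this assay. It differs from compound 1 in one place: 4-(thiophen-2-yl)-1,3-thiazol-2-yl in place of phenylcarbamoyl on a nitrogen on an aromatic ring. Going by the values given here, the only measured single step swapped the aromatic group on the amide-type nitrogen and stayed within the scatter; the values of compound 1 and compound 3 show that a larger rebuild at this position went with a higher number, but no measured step bears directly on the change leading to compound 4. An estimate must therefore rest on the modest movement seen so far, and the step of a 1.2-fold higher number from compound 1 to compound 4 (0.07 log units; within the scatter) is expected to stay within, or only slightly beyond, the scatter. For compound 4 the estimated value is 6500 nM, with a range from 2500 nM to 17000 nM.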

Compound 4, half-maximal inhibitory concentration: 71300 nM
For compound 4 the middle estimate is 11-fold (1.04 log units) below the measured one, outside the stated range (above it).
By their numbers in this assay, from the lowest: compounds 2 and 1 (each within the scatter of the next); then compound 3; then compound 4.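

In this assay, the nitrogen on an aromatic ring turns out to be sensitive to what it carries: putting 4-(thiophen-2-yl)-1,3-thiazol-2-yl in place of phenylcarbamoyl gives a 13-fold higher number from compound 1 to compound 4 (1.11 log units; beyond the scatter) and so a much weaker inhibition, whereas the earlier single swap of phenyl for naphthalen-1-yl gave only a 1.0-fold lower number from compound 1 to compound 2 (0.02 log units; within the scatter) and did not move the number beyond the scatter. The aromatic group on the amide-type nitrogen can therefore change with little effect, yet replacing the whole phenylcarbamoyl group cannot, and this single step changes several things at once: a carbonyl and a hydrogen-bond donor leave, while two five-membered aromatic rings containing sulfur enter. No supporting measurement explains this rise.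

The compounds shown leave open whether the higher number follows the thiophen-2-yl, the 1,3-thiazol-2-yl or the absence of the phenylcarbamoyl group. An unsubstituted 1,3-thiazol-2-yl or a small acetyl group on this same nitrogen would help to pull these possibilities apart.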